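Bromo added to the methoxy-bearing ring of compound 3

The source may report more compounds than this note shows. Statements on the series, on what has been measured and on what is new or still open speak of the compounds shown alone.

Working notes on a set of three measured analogues sharing one core. Compound 1 `CCc1ccccc1-c1nc(N)nc(N)n1` gives 1.65 in a physicochemical assay for lipophilicity; a higher number here means a more lipophilic compound, a lower number a more polar compound. Compound 2 `Nc1nc(N)nc(-c2cc(Br)ccc2Br)n1` gives 2.09. Among the compounds with values here, compound 3 `COc1ccccc1-c1nc(N)nc(N)n1` gives 0.58, the lowest of the three numbers; its nearest neighbour is compound 1, and the single measured step is a number 1.07 log units lower from compound 1 to compound 3 (beyond the scatter).

The next compound is compound 4 `COc1ccc(Br)cc1-c1nc(N)nc(N)n1`, which is to be measured in this assay. It differs from compound 3 by bromo in place of hydrogen on an aromatic carbon. No measured step among these compounds corresponds to this change: compounds 1 and 2 differ in more than one place, so their values can only be set side by side, with compound 2 at 2.09 and compound 1 at 1.65. Within the data shown here, the only measured step bears on the methoxy, not on this change, and gives no direct guide. Based on the behaviour of similar changes in this kind of measurement, a rise beyond the scatter is expected, with the step of a number 0.87 log units higher from compound 3 to compound 4 (beyond the scatter). Compound 4 is therefore estimated at 1.45, with a range from 1.05 to 1.85.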

Compound 4, partition coefficient: 1.53
Compound 4: middle estimate off by 0.08 log units, on the low side; low and high end bracket the measured number.
By their numbers in this assay, from the lowest: compound 3; then compounds 4 and 1 (each within the scatter of the next); then compound 2.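

In this assay, within the data shown here, bromo in place of hydrogen on an aromatic carbon, para to a methoxy group, gives a number 0.95 log units higher from compound 3 to compound 4 (beyond the scatter), the first measured step for this change at this position. Methoxy in place of bromo on an aromatic carbon gives a number 0.56 log units lower from compound 2 to compound 4 (beyond the scatter), and with a number 1.07 log units lower from compound 1 to compound 3 (beyond the scatter) this makes two measured replacements by methoxy that both lower the number, with no compound shown going against this. No measurement among these compounds accounts for either step.

Going by these compounds, whether chloro, an amine or a carboxylic acid in place of bromo at this position would move the number in the same direction remains open. Also open, on these data alone, is whether bromo gives a step of similar size when ethyl stands in place of the methoxy group.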